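The source may report more compounds than this note shows. Statements on the series, on what has been measured and on what is new or still open speak of the compounds shown alone.

Compound 1 `CN(C[C@H]1Cc2ncccc2CN1)[C@H]1CCCc2cccnc21`: 7%
Compound 2 `NC(=O)NC/C=C\CN(C[C@H]1Cc2ncccc2CN1)[C@H]1CCCc2cccnc21`: 1%

In an ADME assay on microsomes from liver (Rattus norvegicus) for metabolic stability, using NADPH, with a stated time of 10 min (on this read-out higher numbers stand for a more stable compound and lower numbers for a less stable compound), compound 2 gives 1%, a number within the usual scatter of compound 1 at 7%. Very little of either compound remains at the end of the test. Compound 3 `NC(=O)NC/C=C/CN(C[C@H]1Cc2ncccc2CN1)[C@H]1CCCc2cccnc21` is closely related to compound 2: the two compounds have the same atoms and bonds and differ only in configuration as drawn: 1 of 3 stereo elements differ; a double bond is drawn Z in compound 2 and E in compound 3. Within the data shown here, only the geometry of that double bond changes, and no measured pair isolates such a change. Among the measured compounds shown here, the nearest evidence is the single measured step, a number 6 percentage points lower from compound 1 to compound 2 (within the scatter). It shows that adding the whole chain left the number within the scatter, so a change in the chain's double-bond geometry gives little reason to predict a large shift. No step beyond the scatter is therefore expected, and the estimated step is a number 2 percentage points higher from compound 2 to compound 3 (within the scatter). For compound 3, the expected value is 3%, with an estimated range of 0% to 10%.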

Compound 3, percent of the compound remaining: 1%
Compound 3: the middle estimate sits 2 percentage points above what was measured, and the stated range covers the measured number.
By their numbers in this assay, from the lowest: compounds 2, 3 and 1 (each within the scatter of the next).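

In this assay, this pair isolates the geometry of the double bond, with no change at the digits printed from compound 2 to compound 3 (within the scatter), and nothing else in the structure changes: the fact that compounds 2 and 3 differ only in the configuration as drawn. With the double bond drawn E, the chain still gives a number 6 percentage points lower from compound 1 to compound 3 (within the scatter), so neither form of the chain stands apart from the compound without it. Very little of any of the three compounds remains at the end of the test, and a read-out this close to its floor leaves little room to show a further drop.

As far as these compounds go, it stays open whether an amine, a carboxylic acid or a longer saturated chain in place of this chain would leave more compound at the end of the test. From the compounds shown here alone, it also stays open whether a change on the shared core would do so.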